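This account rests on a few compounds, and the source may have more. Where it says the series, first, only, none or still open, it means among the compounds named here.

Measured compounds:
Compound 1 `Cc1nc2c(OCc3ccccc3)cccn2c1CO` — in a functional assay on the whole organism (stomach) for inhibition, with Canis familiaris (Canis lupus familiaris) as the target, at a dose of 5 mg/kg by the intravenous route (on this read-out higher numbers stand for a stronger effect at the one dose given and lower numbers for a weaker effect), compound 1 gives 80%.
Compound 2 `Cc1nc2c(OCc3ccccc3)cccn2c1C[S+](C)[O-]` — in this assay compound 2 gives 18%.

Compound 2 stands lowest of the two numbers shown; its nearest neighbour is compound 1, which lies a number 62 percentage points lower from compound 1 to compound 2 (beyond the scatter). The next compound, compound 3 `Cc1nc2c(OCc3ccccc3)cccn2c1CC(=O)O`, differs from compound 2 in one place: a group of 3 heavy atoms (1 carbon, 2 oxygen; no ring) in place of a group of 3 heavy atoms (1 carbon, 1 oxygen, 1 sulfur; no ring), on a saturated chain carbon bound to an aromatic carbon. Among the measured compounds shown here, only one measured step exists, and it is the drop a number 62 percentage points lower from compound 1 to compound 2 (beyond the scatter), which shows that the group leaving in compound 3 is the one tied to the weaker number; no measured step shows what a carboxy group does here. The expectation is therefore uncertain, leaning toward a return upward, and compound 3 is expected to give a step of a number 22 percentage points higher from compound 2 to compound 3 (beyond the scatter) in this assay. Compound 3 is estimated at 40%, within a range from 10% to 70%.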

Compound 3, a percentage reported as inhibition, in the whole organism at one dose (the size of the read-out at that dose, not a potency): 24%
Beside the measured number, compound 3's estimate is 16 percentage points above it; low and high end bracket the measured number.
By their numbers in this assay, from the lowest: compounds 2 and 3 (each within the scatter of the next); then compound 1.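

In this assay, carboxy in place of hydroxy on the saturated chain carbon bound to an aromatic carbon gives a number 56 percentage points lower from compound 1 to compound 3 (beyond the scatter) and so is a second large loss at this place. Carboxy in place of the sulfur-bearing group gives a number 6 percentage points higher from compound 2 to compound 3 (within the scatter) on this read-out, so these two groups cannot be told apart here, and the loss seen earlier is not tied to the sulfur-bearing group alone. Nothing shown here bears on what lies behind these numbers.

The compounds shown leave open whether any other group at this place, such as an amine or a methoxy group, can match the hydroxy of compound 1. They also leave open whether a longer chain ending in hydroxy would keep that number.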